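Methyl on the Core: From Compound 2 to Compound 3

This account rests on a few compounds, and the source may have more. Where it says the series, first, only, none or still open, it means among the compounds named here.

Measured compounds:
compound 1, `O=C(NCc1cccc(Cl)c1)c1ccc2cn(CCn3cccn3)nc2c1`, with 173 nM
compound 2, `CCCN(CC1CCOC1)C(=O)c1ccc2oc(NCc3cccc(Cl)c3)nc2c1`, with 214 nM

Both numbers come from an assay on isolated protein for inhibition of thyroid hormone receptor beta (Homo sapiens), read by fluorescence, with a stated time of 30 min; a lower number here means a stronger inhibitor, a higher number a weaker inhibitor. Compound 2 has the higher of the two values, but compound 1 lies so close to it that the gap falls within the scatter of the measurement, so neither compound can be called the stronger one. Compound 3, `CCCN(CC1CCOC1)C(=O)c1cc(C)c2oc(NCc3cccc(Cl)c3)nc2c1`, differs from compound 2 in one place: methyl in place of hydrogen on an aromatic carbon. For the measured compounds named here, no pair among the measured compounds shows what such a change does on this core, so there is no measured step to lean on. The change is small, and the expectation is for compound 3 to stay close to compound 2, with a step of a 1.1-fold lower number from compound 2 to compound 3 (0.03 log units; within the scatter) that lies within the usual scatter. For compound 3 the estimated value in this assay is 200 nM, with a range from 80 nM to 500 nM.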

Compound 3, half-maximal inhibitory concentration: 35 nM
Estimate against measurement, compound 3: 5.7-fold (0.76 log units) above; the whole stated range lies above it.
By their numbers in this assay, from the lowest: compound 3; then compounds 1 and 2 (each within the scatter of the next).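

In this assay, putting methyl in place of hydrogen on this one aromatic carbon gives a 6.1-fold lower number from compound 2 to compound 3 (0.79 log units; beyond the scatter), so the carbon ortho to a fused ring and meta to a large group is a place where the number responds to a single added heavy atom. Compounds 1 and 2 could not show this, since neither forms a pair with a change at this carbon, and the added methyl brings no ring, hydrogen-bond donor, hydrogen-bond acceptor or net charge. No measurement at hand accounts for the step. The compounds shown leave open whether ethyl, methoxy or chlorine on this same carbon would lower the number further, keep it, or lose the gain. Going by these compounds, whether methyl has a like effect with other groups on the amide nitrogen also remains open, as this is a single pair on one core.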